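Ether chain variants of a terpenoid scaffold on HeLa cells

The source may report more compounds than this note shows. Statements on the series, on what has been measured and on what is new or still open speak of the compounds shown alone.

Compounds measured so far:
- compound 1, `C=C[C@]1(C)CC[C@@H](C(=C)COCC)C[C@H]1C(=C)C`: 106000 nM
- compound 2, `C=C[C@]1(C)CC[C@@H](C(=C)CNC2CCCCC2)C[C@H]1C(=C)C`: 3390 nM
- compound 3, `C=C[C@]1(C)CC[C@@H](C(=C)COCCOC)C[C@H]1C(=C)C`: 238000 nM

All three were tested in a functional assay on HeLa cells (Homo sapiens) for antiproliferative activity, read by WST assay, with a stated time of 24 h; on this read-out lower numbers stand for stronger inhibition and higher numbers for weaker inhibition. Compound 3 stands at the top of the three numbers and is the weakest: its nearest neighbour is compound 1, reached by a 2.2-fold higher number from compound 1 to compound 3 (0.35 log units; beyond the scatter), and the gap to compound 2 is far wider, as a 70-fold higher number from compound 2 to compound 3 (1.85 log units; beyond the scatter) shows. The lone amine in the set, compound 2, sits far below both ethers, with a 31-fold lower number from compound 1 to compound 2 (1.50 log units; beyond the scatter).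

Compound 4, `C=C[C@]1(C)CC[C@@H](C(=C)COCCCC)C[C@H]1C(=C)C`, has not been measured. Relative to compound 3 the change is ethyl in place of methoxy on a saturated chain carbon, two bonds along the chain from an oxygen on a saturated carbon. Within the data shown here, the step that bears on it is the one from compound 1 to compound 3, a modest change in the opposite sense: placing the methoxy raised the number slightly. Taking it away and lengthening the chain to butoxy is therefore expected to give back roughly what the methoxy cost, possibly a little more, but nothing approaching the large shift seen for the amine in compound 2. An estimated modest step of a 3.0-fold lower number from compound 3 to compound 4 (0.47 log units; beyond the scatter) is expected. The estimate for compound 4 in this assay is 80000 nM, with a range from 30000 nM to 200000 nM.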

Compound 4, half-maximal inhibitory concentration: 266000 nM
Compound 4: the middle estimate sits 3.3-fold (0.52 log units) below what was measured; the whole stated range lies below it.
By their numbers in this assay, from the lowest: compound 2; then compound 1; then compounds 3 and 4 (each within the scatter of the next).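

In this assay, butoxy in place of 2-methoxyethoxy on the same saturated chain carbon leaves no difference that can be read (a 1.1-fold higher number from compound 3 to compound 4 (0.05 log units; within the scatter)), so ethyl and methoxy at this place on the chain cannot be told apart. Compound 3 alone could not show whether its step away from the ethoxy of compound 1 depended on the methoxy, but ethyl in place of hydrogen at that same place gives a step in the same direction, also beyond the scatter (a 2.5-fold higher number from compound 1 to compound 4 (0.40 log units; beyond the scatter)), so the step does not require the oxygen of the methoxy. Butoxy also stands as far from cyclohexylamino as the other ethers do (a 78-fold higher number from compound 2 to compound 4 (1.89 log units; beyond the scatter)), which means that neither ether extension in this set comes close to the number of the amine in compound 2.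

Nothing at hand accounts for these numbers. Still open, as far as these compounds go, is whether a longer chain such as hexyloxy, a hydroxyl at the end of the chain, or another amine such as piperidine or morpholine would keep the number of the ethers or approach that of compound 2.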